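Trimming the Chain of Compound 2

The compounds below may be only part of what the source reports. "The series", "measured", "known", "first", "only" and "open" are said of these compounds alone.

In a functional assay on A549 cells (Homo sapiens) for antiproliferative activity, read by MTT assay, with a stated time of 72 h (on this read-out higher numbers stand for weaker inhibition and lower numbers for stronger inhibition), compound 1 (`CCCCCCCCCNC[C@@H]1OC[C@H](N)[C@H]1O`) reports > 128000 nM as a limit and not a number. Among the compounds with values here, compound 2 (`CCCCCCCCCCCCNC[C@@H]1OC[C@H](N)[C@@H]1O`) gives 5870 nM and is the only compound with a true number so far. Compound 3 (`CCCCCCCCCNC[C@@H]1OC[C@H](N)[C@@H]1O`) has a shorter chain than compound 2, and hydrogen in place of propyl on a saturated chain carbon, nine bonds along the chain from an amine nitrogen is the counted change, with hydrogen in place of propyl on a saturated chain carbon, nine bonds along the chain from an amine nitrogen. Within the data shown here, no measured step gauges this kind of change, so its size remains an expectation. A weakening beyond the usual scatter is expected in this assay and would appear as a higher number for compound 3. The estimated change is a 5.1-fold higher number from compound 2 to compound 3 (0.71 log units; beyond the scatter) and rests on the structural change alone. For compound 3 the expected value is 30000 nM within an estimated range of 10000 nM to 128000 nM in this assay.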

Compound 3, half-maximal inhibitory concentration: 22100 nM
Estimate against measurement, compound 3: 1.4-fold (0.13 log units) above; measured number inside the range.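

Hydrogen in place of propyl, on a saturated chain carbon, nine bonds along the chain from an amine nitrogen, has a real cost in this assay: the result is a 3.8-fold higher number from compound 2 to compound 3 (0.58 log units; beyond the scatter). With the shorter chain held fixed, the drawn configuration at a saturated ring carbon also counts, with an at least 5.7-fold lower number from compound 1 to compound 3 (0.76 log units; beyond the scatter), and this step rests on configuration alone: the fact that compounds 1 and 3 differ only in the configuration as drawn. Compound 1 stands at a limit and not a number, so the full size of that step stays unknown: the limit of > 128000 nM in this assay, at which 1 of the 3 values shown sits.

On these data alone, two chain lengths fix no trend, and whether a longer chain than that of compound 2 would lower the number further remains open. Also open, as far as these compounds go, is whether the same change of configuration matters with the chain of compound 2, and whether a carboxylic acid in place of the chain would keep any activity.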